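A Fluoro Swap on the Phenyl Ring of Compound 3

The source may hold more compounds than are shown below. What is called first, only, known or untested is meant among the compounds shown, and "the series" means these compounds.

Of the compounds shown here, three sharing one core have been tested in a functional assay on NUGC-3 cells (Homo sapiens) for antiproliferative activity, read by sulforhodamine B assay; a lower number here means a stronger inhibitor of growth, a higher number a weaker inhibitor of growth. Compound 1 `COc1ccccc1NC(=O)Nc1nc2ccc(F)cc2s1` gives > 10 ug/mL, which is a limit of the assay rather than a number. Compound 2 `COc1ccc(NC(=O)Nc2nc3ccc(F)cc3s2)cc1` gives > 10 ug/mL, again a limit. Compound 3 `O=C(Nc1ccccc1)Nc1nc2ccc(F)cc2s1` gives > 10 ug/mL, also a limit, so compound 3 stands at the limit of > 10 ug/mL in this assay, at which 3 of the 3 values shown sit. The step that the two limits leave unreadable from compound 1 to compound 3 and the step that the two limits leave unreadable from compound 2 to compound 3, each a hydrogen in place of methoxy on an aromatic carbon, therefore cannot be sized. Compound 4 `O=C(Nc1nc2ccc(F)cc2s1)Nc1ccccc1F` differs from compound 3 by fluoro in place of hydrogen on an aromatic carbon, phenyl to 2-fluorophenyl. For the measured compounds named here, no measured step bears on this change and the three limits give no direction, so the expected step is a step that the limit leaves unreadable from compound 3 to compound 4, nothing beyond the scatter. Compound 4 is estimated at 15 ug/mL, expected between 5 ug/mL and 50 ug/mL in this assay.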

Compound 4, concentration for 50% growth inhibition: > 10 ug/mL
Compound 4: only a limit was reported (the forecaster's own chance of this, stated with the estimate: 80%); the middle value lies beyond the limit too.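

Compound 4 gives > 10 ug/mL, again a limit. No step from compound 1 or compound 3 to compound 4 can be read, since all sit at the same limit: the limit of > 10 ug/mL in this assay, at which 4 of the 4 values shown sit.

The compounds shown leave open whether fluoro, methoxy or hydrogen on the phenyl ring makes any difference in this assay.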